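A few compounds are considered here, and "the series" means these few. Any claim that something is new, unique, unknown or untested is made for them only; others in the source may bear on it.

Measured in a functional assay on NPC-TW01 cells (Homo sapiens) for inhibition, read by MTT assay, with a stated time of 72 h; a higher number here means a weaker inhibitor of growth, a lower number a stronger inhibitor of growth:
Compound 1 `Cc1ccc(-c2cc(N)n(-c3cccc(Cl)c3)n2)cc1`: > 100000 nM, a limit of the assay
Compound 2 `Cc1ccc(-c2nn(-c3cccc(Cl)c3)c(/N=C/N(C)C)c2C=O)cc1`: 7200 nM
Compound 3 `CN(C)/C=N/c1c(C=O)c(-c2ccc(Cl)cc2)nn1-c1cccc(Cl)c1`: 7400 nM

Among the measured compounds shown here, only two of these values are true numbers, and they match: a 1.0-fold higher number from compound 2 to compound 3 (0.01 log units; within the scatter). Compound 1 sits at the limit of > 100000 nM in this assay, at which 1 of the 3 values shown sits.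

Compound 4 `Cc1ccc(-c2nn(-c3cccc(Cl)c3)c(N)c2C=O)cc1` differs from compound 2 by one nitrogen atom in place of a group of 5 heavy atoms (3 carbon, 2 nitrogen; no ring), on an aromatic carbon: one nitrogen atom, an amino group, replaces a group of 5 heavy atoms on an aromatic carbon. For the measured compounds named here, the one measured step swaps chloro for methyl, a different change, so it offers little guidance. Compound 1 also carries the amino group, though no formyl group, and gives > 100000 nM, which is a limit. A clearly higher number is therefore expected in this assay, with an expected size of a 3.5-fold higher number from compound 2 to compound 4 (0.54 log units; beyond the scatter). Compound 4 is estimated at 25000 nM, within an expected range of 7000 nM to 90000 nM.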

Compound 4, concentration for 50% growth inhibition: > 100000 nM
Compound 4: only a limit was reported; the forecaster's own chance of this, stated with the estimate: 35%; middle value at least 4.0-fold (0.60 log units) from the limit.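

At this ring carbon, the amino group does not keep the growth inhibition seen with the larger group of 5 heavy atoms: the change gives an at least 13-fold higher number from compound 2 to compound 4 (1.14 log units; beyond the scatter). Compound 4 gives only a limit, and it shares that limit with compound 1: the limit of > 100000 nM in this assay, at which 2 of the 4 values shown sit. Carrying a formyl group therefore does not bring the amino compound 4 to a measurable number, and the step between compound 1 and compound 4 cannot be read.

As far as these compounds go, what remains open is how much of the larger group this position needs. A methylamino or an acetamide group at this carbon would test whether something only slightly larger than amino restores a measurable number.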